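The source may hold more compounds than are shown below. What is called first, only, known or untested is meant among the compounds shown, and "the series" means these compounds.

In an ADME assay on a cell-free system (serum, Homo sapiens) for pharmacokinetics, read by HPLC, tested at 200 uM (on this read-out higher numbers stand for a longer-lived compound and lower numbers for a shorter-lived compound), three compounds built on the shared core have been characterised. Compound 1 `O=C(CCOc1nonc1S(=O)(=O)c1ccccc1)Oc1ccccc1C(=O)O` gives 0.583 h. Compound 2 `O=C(CCOc1nonc1-c1ccccc1)Oc1ccccc1C(=O)O` gives 0.667 h, and the step of a 1.1-fold higher number from compound 1 to compound 2 (0.06 log units; within the scatter) shows that exchanging the group on that aromatic carbon leaves the half-life essentially where it was. Compound 3 `NC(=O)c1c(CSCC(=O)Oc2ccccc2C(=O)O)no[n+]1[O-]` gives 0.45 h; on paper its number is the smallest of the three, but its separation from compound 1 and from compound 2 falls within the scatter, so the three compounds cannot be ranked against one another.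

Compound 4 `N#Cc1c(CSCC(=O)Oc2ccccc2C(=O)O)no[n+]1[O-]` is the next member. It differs from compound 3 by cyano in place of carbamoyl on an aromatic carbon. Going by the values given here, the only measured step, a 1.1-fold higher number from compound 1 to compound 2 (0.06 log units; within the scatter), concerns a different place on a different core and a different pair of groups, so no measured step bears directly on this change; what the series does show is that the one single-point change tested so far, and the gaps between all three measured compounds, remained within the scatter. On that basis a step of no change at the digits printed from compound 3 to compound 4 (within the scatter) is expected, meaning no movement beyond the scatter. Compound 4 is therefore estimated to give 0.45 h in this assay, with a range from 0.25 h to 0.8 h.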

Compound 4, half-life in the serum assay: 0.217 h
Estimate against measurement, compound 4: 2.1-fold (0.32 log units) above, and the stated range ends above it.
By their numbers in the serum assay, from the lowest: compound 4; then compounds 3, 1 and 2 (each within the scatter of the next).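

In the serum assay, cyano in place of carbamoyl on the aromatic carbon next to the ring nitrogen gives a 2.1-fold lower number from compound 3 to compound 4 (0.32 log units; beyond the scatter), the only single-place change shown so far that moves the half-life beyond the scatter, so the group at this position can matter in serum. In a physicochemical assay for pharmacokinetics, read by HPLC, in phosphate buffer, at pH 7.4, tested at 100 uM (on this read-out lower numbers stand for a shorter-lived compound and higher numbers for a longer-lived compound), compound 3 gives 0.75 h and compound 4 gives 0.55 h, and the physicochemical assay records a 1.4-fold lower number from compound 3 to compound 4 (0.13 log units; within the scatter), so in buffer alone the two compounds cannot be told apart and the clear separation appears only in serum. Nothing available explains why the change registers in serum and not in buffer.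

This single pair cannot show whether the shorter serum half-life of compound 4 goes with the loss of the hydrogen-bond donor that leaves with carbamoyl or with another difference between the two groups. Going by these compounds, it also remains open how an amine or a methyl ester on the same aromatic carbon would behave in the serum assay, and whether the same exchange would have a similar result elsewhere.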